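The source may report more compounds than this note shows. Statements on the series, on what has been measured and on what is new or still open speak of the compounds shown alone.

Measured in a functional assay on HCT-15 cells (Homo sapiens) for cytotoxicity, read by ELISA, with a stated time of 4 days; a higher number here means a weaker inhibitor, a lower number a stronger inhibitor:
compound 1 `Cc1ccsc1-c1cc(-c2ccco2)cc(-c2ccc(Cl)cc2)n1`: 710 nM
compound 2 `Cc1ccsc1-c1cc(-c2ccc(Cl)o2)cc(-c2cccc(Cl)c2)n1`: 26400 nM

Compound 2 has the higher of the two numbers, and its gap to compound 1 lies beyond the scatter. Compound 3 `Cc1ccsc1-c1cc(-c2ccc(Cl)o2)cc(-c2ccc(Cl)cc2)n1` differs from compound 2 in one place: 4-chlorophenyl in place of 3-chlorophenyl on an aromatic carbon. Among the measured compounds shown here, no measured pair isolates this change, so its size remains unknown. Compound 1 also bears 4-chlorophenyl and gives 710 nM, though it differs elsewhere as well. A fall beyond the scatter in this assay is therefore expected, with caution. The expected change is a 6.6-fold lower number from compound 2 to compound 3 (0.82 log units; beyond the scatter). The estimated value for compound 3 is 4000 nM, with an expected range of 700 nM to 22000 nM.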

Compound 3, half-maximal inhibitory concentration: 30300 nM
Estimate against measurement, compound 3: 7.6-fold (0.88 log units) below; the whole stated range lies below it.
By their numbers in this assay, from the lowest: compound 1; then compounds 2 and 3 (each within the scatter of the next).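

In this assay, 4-chlorophenyl in place of 3-chlorophenyl on this aromatic carbon gives a 1.1-fold higher number from compound 2 to compound 3 (0.06 log units; within the scatter), so with the 5-chlorofuran-2-yl group present, the two chlorophenyl isomers are not separated. The large step lies elsewhere: chloro in place of hydrogen on an aromatic carbon gives a 43-fold higher number from compound 1 to compound 3 (1.63 log units; beyond the scatter). No available data explain either step.

Open, from the compounds shown here alone, is whether the 3-chlorophenyl and 4-chlorophenyl groups also match when that chloro is replaced by hydrogen. Also open, going by these compounds, is how an amine or a carboxylic acid on the phenyl ring would read in this assay.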